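Fluorophenyl series: moving fluoro on the aryl ketone

This account rests on a few compounds, and the source may have more. Where it says the series, first, only, none or still open, it means among the compounds named here.

Measured compounds:
- compound 1 `O=C(/C=C/c1ccc2c(c1)B(O)OC2)c1ccc(F)cc1`: 1400 nM
- compound 2 `O=C(/C=C/c1ccc2c(c1)B(O)OC2)c1ccc(C(F)(F)F)cc1`: 3700 nM
- compound 3 `CCOC(=O)c1ccc(C(=O)/C=C/c2ccc3c(c2)B(O)OC3)cc1`: 7100 nM

In a functional assay on SK-OV-3 cells (Homo sapiens) for cytotoxicity, read by MTT assay, with a stated time of 48 h (a lower number here means a stronger inhibitor, a higher number a weaker inhibitor), compound 1 stands lowest of the three numbers; the nearest is compound 2 a 2.6-fold higher number from compound 1 to compound 2 (0.42 log units; beyond the scatter) and the furthest is compound 3 a 5.1-fold higher number from compound 1 to compound 3 (0.71 log units; beyond the scatter), both beyond the scatter. The step between compound 2 and compound 3 a 1.9-fold higher number from compound 2 to compound 3 (0.28 log units; within the scatter) stays within the scatter.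

Compound 4 `O=C(/C=C/c1ccc2c(c1)B(O)OC2)c1cccc(F)c1` differs from compound 1 only in the position of the fluorine: 3-fluorophenyl in place of 4-fluorophenyl on a carbonyl carbon. Among the measured compounds shown here, none of the measured steps bears directly on this change; each of them replaces the fluoro by another group on the same aromatic carbon rather than moving it. The two steps that do exist show that altering this aryl group shifts the number only modestly, and nothing in the shared core changes here. A step within the scatter is therefore expected, with no clear direction, for compound 4 a 1.3-fold higher number from compound 1 to compound 4 (0.11 log units; within the scatter). The estimate for compound 4 in this assay is 1800 nM, with a range from 700 nM to 4500 nM.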

Compound 4, half-maximal inhibitory concentration: 4800 nM
Compound 4: middle estimate off by 2.7-fold (0.43 log units), on the low side; measured number outside the range, above it.
By their numbers in this assay, from the lowest: compound 1; then compounds 2, 4 and 3 (each within the scatter of the next).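

In this assay, moving the fluorine alone gives a 3.4-fold higher number from compound 1 to compound 4 (0.54 log units; beyond the scatter), so 3-fluorophenyl in place of 4-fluorophenyl on a carbonyl carbon is a step beyond the scatter. The earlier steps shown here all replaced the fluoro by another group, so they could not show that the place of the fluorine on this aromatic ring matters by itself, with the atoms unchanged and the counted donors and acceptors the same. No measurement is available that accounts for this step.

From the compounds shown here alone, what the same move does with trifluoromethyl or ethoxycarbonyl in place of the fluoro remains open. Going by these compounds, it is also open whether an amine or a carboxylic acid on that aromatic carbon would give a number close to that of compound 1.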